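Swapping a hydroxy-bearing chain for a methoxybenzyl group

The source may hold more compounds than are shown below. What is called first, only, known or untested is meant among the compounds shown, and "the series" means these compounds.

Of the compounds shown here, three sharing one core have been measured in an assay on cells for inhibition of interleukin-5 receptor subunit alpha (Mus musculus), read by WST assay, with a stated time of 48 h, in the presence of a further agent that is not named here; a lower number here means a stronger inhibitor, a higher number a weaker inhibitor. Compound 3 `CCCC(CO)NCc1nc2c(OCC3CCCCC3)cccc2[nH]1` stands at the low end of the numbers: in this assay compound 3 gives 7500 nM. Compound 1 `OCCNCc1nc2c(OCC3CCCCC3)cccc2[nH]1` gives 20000 nM. Compound 2 `OCCCCCNCc1nc2c(OCC3CCCCC3)cccc2[nH]1` returns only a limit of the assay, > 30000 nM, so no exact number is known for it.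

The step to compound 4 `COc1ccc(CNCc2nc3c(OCC4CCCCC4)cccc3[nH]2)cc1` is 4-methoxybenzyl in place of 1-(hydroxymethyl)butyl on an amine nitrogen. Among the measured steps, the closest in kind is a 2.7-fold lower number from compound 1 to compound 3 (0.43 log units; beyond the scatter), which shows that adding carbon on the chain carbon bound to the amine nitrogen lowered the number. In contrast, an at least 1.5-fold higher number from compound 1 to compound 2 (0.17 log units; that floor lies within the scatter) shows that lengthening the hydroxy chain did not help, and an at least 4.0-fold lower number from compound 2 to compound 3 (0.60 log units; beyond the scatter) points the same way. None of these steps removes the hydroxy donor or introduces an aromatic ring, so the present change reaches beyond what has been tested, and the expected direction is uncertain. On balance, a step of roughly a 1.5-fold lower number from compound 3 to compound 4 (0.18 log units; within the scatter) is expected, staying near compound 3 with the possibility of a modest gain. Compound 4 is therefore estimated at 5000 nM, with a range from 1500 nM to 20000 nM.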

Compound 4, half-maximal inhibitory concentration: > 30000 nM
Compound 4 ended at the assay's limit; the forecaster's own chance of this, stated with the estimate: 15%; at least 6.0-fold (0.77 log units) between middle value and limit.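

Within the data shown here, putting 4-methoxybenzyl in place of 1-(hydroxymethyl)butyl on the amine nitrogen brings an at least 4.0-fold higher number from compound 3 to compound 4 (0.60 log units; beyond the scatter) in this assay, so adding carbon on this nitrogen does not by itself lower the number, as the earlier steps might have suggested. This is also the first change shown that brings in an aromatic ring and leaves the group on this nitrogen with no hydrogen-bond donor, yet the comparison with the short hydroxy chain stays less firm: an at least 1.5-fold higher number from compound 1 to compound 4 (0.17 log units; that floor lies within the scatter), so those two compounds cannot be separated. Compound 4 gives > 30000 nM, which is a limit of the assay, and its step against compound 2 cannot be read: the limit of > 30000 nM in this assay, at which 2 of the 4 values shown sit.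

The compounds shown leave open whether the higher number goes with the lost hydroxy group or with the aromatic ring, as compound 4 changes both at once. A 4-hydroxybenzyl group on the amine nitrogen, which keeps the ring and a hydroxy group, or a plain butyl chain, which keeps the chain and drops the hydroxy group, would pull these two changes apart.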